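A few compounds are considered here, and "the series" means these few. Any claim that something is new, unique, unknown or untested is made for them only; others in the source may bear on it.

Measured in an ADME assay on Vero cells (Chlorocebus sabaeus) for cytotoxicity, read by resazurin assay, with a stated time of 2 days; a lower number here means that less compound is tolerated, a higher number that more compound is tolerated:
- Compound 1 `O=C(/C=C/c1cccc(NC(=S)Nc2ccccc2)c1)C[C@@H]1O[C@H](CO)[C@@H](O)[C@H](O)[C@H]1O`: 371000 nM
- Compound 2 `Cc1ccc(S(=O)(=O)Nc2cccc(/C=C/C(=O)C[C@@H]3O[C@H](CO)[C@@H](O)[C@H](O)[C@H]3O)c2)cc1`: 381000 nM
- Compound 3 `O=C(/C=C/c1cccc(NC(=S)Nc2ccccc2)c1)C[C@@H]1OC[C@@H](O)[C@H](O)[C@H]1O`: 289000 nM

All three compounds are tolerated only at high concentrations, and the numbers sit close together. Compound 3, at 289000 nM, cannot be told apart from the other two. The comparison with its first neighbour gives a 1.3-fold lower number from compound 1 to compound 3 (0.11 log units; within the scatter), where hydrogen stands in place of hydroxymethyl on a saturated ring carbon. The values of compound 2 and compound 3 also lie within the scatter of each other.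

The next compound to consider is compound 4 `Cc1ccc(S(=O)(=O)Nc2cccc(/C=C/C(=O)C[C@@H]3OC[C@@H](O)[C@H](O)[C@H]3O)c2)cc1`. It differs from compound 3 as follows: a group of 10 heavy atoms (7 carbon, 2 oxygen, 1 sulfur; one six-membered aromatic ring of carbon only) in place of a group of 9 heavy atoms (7 carbon, 1 nitrogen, 1 sulfur; one six-membered aromatic ring of carbon only), on a nitrogen on an aromatic ring. In short, a (4-methylphenyl)sulfonyl group enters on a nitrogen on an aromatic ring.

The same exchange of groups has been measured once, on the compounds that carry the hydroxymethyl, and it gave a 1.0-fold higher number from compound 1 to compound 2 (0.01 log units; within the scatter). That single step is the closest guide, and the hydrogen-for-hydroxymethyl step above adds no sign of a larger effect in this assay. Whether the exchange behaves the same way on compound 3 has not been measured. The expected result is therefore no change beyond the scatter, with the estimated step being a 1.0-fold higher number from compound 3 to compound 4 (0.01 log units; within the scatter). For compound 4 the estimated value is 297000 nM, with an expected range from 170000 nM to 500000 nM.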

Compound 4, half-maximal cytotoxic concentration: 94700 nM
The estimate for compound 4 lay 3.1-fold (0.50 log units) above the measured number; the whole stated range lies above it.
By their numbers in this assay, from the lowest: compound 4; then compounds 3, 1 and 2 (each within the scatter of the next).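

In this assay, the (4-methylphenyl)sulfonyl group on a nitrogen on an aromatic ring turns out not to be a neutral exchange on every core. On the core lacking the hydroxymethyl it gives a 3.1-fold lower number from compound 3 to compound 4 (0.48 log units; beyond the scatter), so the same change does not give the same step on the two cores: the same change on two cores in this assay, a 1.0-fold higher number (0.01 log units; within the scatter) from compound 1 to compound 2 and a 3.1-fold lower number (0.48 log units; beyond the scatter) from compound 3 to compound 4, 3.1-fold (0.50 log units) apart, beyond the scatter of two such steps Read from the other direction, hydrogen in place of hydroxymethyl on a saturated ring carbon gives a 4.0-fold lower number from compound 2 to compound 4 (0.60 log units; beyond the scatter) when the (4-methylphenyl)sulfonyl group is present, so the size of this step also depends on the group carried on the nitrogen: the same change on two cores in this assay, a 1.3-fold lower number (0.11 log units; within the scatter) from compound 1 to compound 3 and a 4.0-fold lower number (0.60 log units; beyond the scatter) from compound 2 to compound 4, 3.1-fold (0.50 log units) apart, beyond the scatter of two such steps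

These four compounds form a single set of paired changes, so they cannot show whether the dependence between the two places is general, and they give no reason for it. From the compounds shown here alone, it remains open whether a smaller group on the nitrogen, such as acetyl or methanesulfonyl, would behave like the (4-methylphenyl)sulfonyl group, and whether a methyl group or a carboxylic acid on that saturated ring carbon would act like the hydroxymethyl.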